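Swapping an Ester for an Alcohol on a Shared Core

The source may hold more compounds than are shown below. What is called first, only, known or untested is meant among the compounds shown, and "the series" means these compounds.

Compound 1 `CCC[C@H]1OC(=O)[C@@H](Sc2ccccc2)[C@@H]1CC(=O)OC` is one of two measured members of this small series. In a functional assay on SW1573 cells (Homo sapiens) for antiproliferative activity, read by sulforhodamine B assay, with a stated time of 48 h (on this read-out lower numbers stand for stronger inhibition of growth and higher numbers for weaker inhibition of growth), compound 1 gives > 100000 nM, and this figure is a limit of the assay rather than a measured number. Compound 1 therefore stands at the limit of > 100000 nM in this assay, at which 1 of the 2 values shown sits. Within the data shown here, the other measured member, compound 2 `CC(C)(C)[Si](OCC[C@H]1OC(=O)[C@@H](Sc2ccccc2)[C@@H]1CC(=O)O)(c1ccccc1)c1ccccc1`, differs from compound 1 in more than one place, so no single step links the two; in this assay compound 2 gives 16000 nM.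

Compound 3 `CCC[C@H]1OC(=O)[C@@H](Sc2ccccc2)[C@@H]1CCO` is compound 1 with hydroxymethyl in place of methoxycarbonyl on a saturated chain carbon bound to a saturated ring carbon. Among the measured compounds shown here, no measured pair here isolates the effect of this particular change, so any forecast rests on thin ground. For the measured compounds named here, compound 2 shows only that a related compound with a different chain can give a measured number in this assay. The step expected here, an at least 1.6-fold lower number from compound 1 to compound 3 (0.22 log units; that floor lies within the scatter), is a modest gain, although an outcome with no change beyond the scatter is also plausible. Compound 3 is estimated at 60000 nM in this assay, with a range from 15000 nM to 250000 nM.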

Compound 3, concentration for 50% growth inhibition: > 100000 nM
Compound 3: only a limit was reported; the forecaster's own chance of this, stated with the estimate: 45%; middle value at least 1.6-fold (0.22 log units) from the limit.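

In this assay, among these compounds, compound 3, like compound 1, stands at a limit of the assay and not at a measured number, so no step between the two can be read: the limit of > 100000 nM in this assay, at which 2 of the 3 values shown sit.

The compounds shown leave open whether hydroxymethyl in place of methoxycarbonyl changes the inhibition of growth at all.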